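Ring size at the thiocarbonyl: compound 2 to compound 3

A few compounds are considered here, and "the series" means these few. Any claim that something is new, unique, unknown or untested is made for them only; others in the source may bear on it.

Within the data shown here, compound 2 `Cc1cccc(/C(N)=N/NC(=S)N2CCCCC2)n1` gives 2000 nM in a functional assay on HeLa cells (Homo sapiens) for cytotoxicity, read by MTT assay, with a stated time of 72 h (a lower number here means a stronger inhibitor, a higher number a weaker inhibitor), the lower of the two numbers measured so far, though the gap to compound 1 is within the scatter. Compound 1 `Cc1cccc(/C(N)=N/NC(=S)N2CCOCC2)n1` gives 2200 nM in this assay. Among the measured compounds shown here, the one measured step that bears on the change at hand is the exchange at the thiocarbonyl carbon, a 1.1-fold lower number from compound 1 to compound 2 (0.04 log units; within the scatter), which did not move the number beyond the scatter. Compound 3 `Cc1cccc(/C(N)=N/NC(=S)N2CCCC2)n1` carries the next variation at the same place: pyrrolidin-1-yl in place of piperidin-1-yl on a thiocarbonyl carbon. For the measured compounds named here, no shift beyond the scatter is expected from compound 2 to compound 3 in this assay, given that the only comparable exchange, a 1.1-fold lower number from compound 1 to compound 2 (0.04 log units; within the scatter), stayed within the scatter. The expected step is no change at the digits printed from compound 2 to compound 3 (within the scatter). Compound 3 is estimated to give 2000 nM in this assay, with a range from 1000 nM to 4000 nM.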

Compound 3, half-maximal inhibitory concentration: 2700 nM
Beside the measured number, compound 3's estimate is 1.4-fold (0.13 log units) below it; the measured number falls inside the stated range.
By their numbers in this assay, from the lowest: compounds 2, 1 and 3 (each within the scatter of the next).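

In this assay the thiocarbonyl carbon accepts a five-membered ring as well as six-membered ones, with pyrrolidin-1-yl in place of piperidin-1-yl showing a 1.4-fold higher number from compound 2 to compound 3 (0.13 log units; within the scatter) and pyrrolidin-1-yl in place of morpholin-4-yl showing a 1.2-fold higher number from compound 1 to compound 3 (0.09 log units; within the scatter). Across compound 1, compound 2 and compound 3, neither ring size nor the ring oxygen of morpholin-4-yl separates the numbers beyond the scatter at this place. No supporting measurement is available to account for this flat reading.

From the compounds shown here alone, whether an open-chain diethylamino group, a seven-membered azepan-1-yl ring or a 4-methylpiperazin-1-yl ring on the same carbon would leave the scatter remains open. Also open, going by these compounds, is how the series would respond if the methyl group of the shared core gave way to a carboxylic acid.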